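The compounds below may be only part of what the source reports. "The series", "measured", "known", "first", "only" and "open" are said of these compounds alone.

Measured so far:
- compound 1, `O=C(Nc1ccc(C(F)(F)F)cc1)C1CCc2ccccc2N1`, in a functional assay on HCT-15 cells (Homo sapiens) for cytotoxicity, read by sulforhodamine B assay, with a stated time of 72 h (a higher number here means a weaker inhibitor of growth, a lower number a stronger inhibitor of growth), compound 1 gives 17600 nM
- compound 2, `CCCC(=O)N1c2ccccc2CCC1C(=O)Nc1ccccc1C(F)(F)F`, in this assay compound 2 gives > 70000 nM, which is a limit of the assay and not a number

Among the measured compounds shown here, compound 2 therefore stands only at the edge of what this assay can resolve; the limit of > 70000 nM in this assay, at which 1 of the 2 values shown sits, is all that is known of it, and no step between it and compound 1 can be sized. The unmeasured compound 3, `O=C(Nc1ccccc1C(F)(F)F)C1CCc2ccccc2N1C(=O)c1cccc(Cl)c1`, differs from compound 2 in one place: 3-chlorophenyl in place of propyl on a carbonyl carbon. For the measured compounds named here, no measured step covers an exchange of this kind, so the account can only say what the two recorded values show: compound 1 sits at a measurable concentration, compound 2 at a limit. Given that compound 2 is recorded only as a limit, the step of an at least 1.5-fold lower number from compound 2 to compound 3 (0.19 log units; that floor lies within the scatter) is expected to be small in size and of uncertain direction, quite possibly not beyond the usual scatter. Compound 3 is accordingly estimated at 45000 nM in this assay, within a range from 10000 nM to 70000 nM, with a real chance that the assay again reports only a limit.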

Compound 3, concentration for 50% growth inhibition: 797 nM
Compound 3: middle estimate off by 56-fold (1.75 log units), on the high side; the measured number lies below the stated range.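

In this assay, among the compounds shown here, 3-chlorophenyl in place of propyl on a carbonyl carbon whose other neighbour is an amide-type nitrogen in a ring gives an at least 87-fold lower number from compound 2 to compound 3 (1.94 log units; beyond the scatter), so what this carbonyl carries can decide whether growth inhibition is seen at all, which the earlier compounds could not show. Compound 2 gives > 70000 nM, which is a limit of the assay and not a number. From the compounds shown here alone, the step is therefore a floor and its full size remains unknown, because compound 2 is known only through this limit: the limit of > 70000 nM in this assay, at which 1 of the 3 values shown sits.

Still open, going by these compounds, is whether the step belongs to the aromatic ring or to the chlorine, a question that an unsubstituted phenyl, a cyclohexyl or a longer alkyl chain on the same carbonyl carbon would help to settle. On these data alone, compound 1 differs from compound 3 in more than one place, so it offers no clean comparison here, and it remains open whether the exchange would carry over to a core with the trifluoromethyl placed as in compound 1.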